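Butoxy to fluoro: a step with little measured guidance

The source may hold more compounds than are shown below. What is called first, only, known or untested is meant among the compounds shown, and "the series" means these compounds.

Measured in a functional assay on SGC-7901 cells (Homo sapiens) for antiproliferative activity, read by MTT assay, with a stated time of 24 h; on this read-out lower numbers stand for stronger inhibition and higher numbers for weaker inhibition:
- compound 1 `O=C(NNc1ccccc1Cl)c1ccccc1NS(=O)(=O)c1cnc(O)nc1O`: > 20000 nM (a limit)
- compound 2 `O=C(NNc1ccc(F)cc1)c1ccccc1NS(=O)(=O)c1cnc(O)nc1O`: > 20000 nM (a limit)
- compound 3 `CCCCOc1ccc(C(=O)NNC(=O)c2ccccc2NS(=O)(=O)c2cnc(O)nc2O)cc1`: 6890 nM

In this assay, within the data shown here, compound 3 gives 6890 nM as the only true number of the set. The other two results are the limit of > 20000 nM in this assay, at which 2 of the 3 values shown sit, and they give no exact distance to compound 3.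

Compound 4 `O=C(NNC(=O)c1ccccc1NS(=O)(=O)c1cnc(O)nc1O)c1ccc(F)cc1` has not yet been measured. It differs from compound 3 by fluoro in place of butoxy on an aromatic carbon, para to a large group fluoro in place of butoxy on an aromatic carbon and the same difference reads 4-butoxyphenyl to 4-fluorophenyl.

Among the measured compounds shown here, the only measured step, a step that the two limits leave unreadable from compound 1 to compound 2 offers no size to carry over to this change. Compound 2 also holds a 4-fluorophenyl group, though on an amine nitrogen, and its > 20000 nM is a limit. That limit is the sole hint of direction, so weaker inhibition is expected, with low confidence and with a real chance that only a limit will be reported. The expected change is an estimated 2.0-fold higher number from compound 3 to compound 4 (0.31 log units; beyond the scatter) in this assay and its size remains uncertain. For compound 4 the estimate is 14000 nM with an expected range of 5000 nM to 35000 nM in this measurement.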

Compound 4, half-maximal inhibitory concentration: > 20000 nM
Compound 4: only a limit was reported; the forecaster's own chance of this, stated with the estimate: 40%; middle value at least 1.4-fold (0.15 log units) away from the limit.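

In this assay, among these compounds, the exchange of butoxy for fluoro on an aromatic carbon, para to a large group, gives the first step in this set with a readable size: an at least 2.9-fold higher number from compound 3 to compound 4 (0.46 log units; beyond the scatter). Going by these compounds, the result for compound 4 is a limit and not a number, so this size is a minimum and the true distance remains unknown. Among the compounds shown, the only exact value therefore stays with compound 3, the one compound carrying the 4-butoxyphenyl group, and compound 4, with its 4-fluorophenyl group, falls in with the others: the limit of > 20000 nM in this assay, at which 3 of the 4 values shown sit.

The steps from compound 1 and from compound 2 to compound 4 cannot be read, as both ends of each are limits, so the compounds shown do not tell how the two linkers or the aromatic groups on them compare. On these data alone, it also stays open whether a methoxy group, a longer alkoxy chain such as hexyloxy, or a hydrogen at this place would give an exact value, and how such a value would stand against that of compound 3.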